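Lengthening the Alkyl Chain on an Aryl Urea

The source may report more compounds than this note shows. Statements on the series, on what has been measured and on what is new or still open speak of the compounds shown alone.

Measured compounds:
compound 1 `CCCc1ccc(NC(=O)N[C@H](C)c2ccccc2)cc1` — 33%
compound 2 `CCCCc1ccc(NC(=O)N[C@H](C)c2ccccc2)cc1` — 100%

In an ADME assay on the whole organism with Oryza sativa as the target, tested at 0.1 uM (a lower number here means a stronger effect, a higher number a weaker effect of the compound at the concentration tested), compound 1 gives 33%, while compound 2 gives 100%. For the measured compounds named here, of the two numbers, compound 2 stands highest, separated from compound 1 by the single measured step, a number 67 percentage points higher from compound 1 to compound 2 (beyond the scatter), which comes from a methyl in place of hydrogen on a saturated chain carbon, three bonds along the chain from an aromatic carbon. Compound 3 `CCCCCCc1ccc(NC(=O)N[C@H](C)c2ccccc2)cc1` has not yet been measured in this assay. It differs from compound 2 by ethyl in place of hydrogen on a saturated chain carbon, four bonds along the chain from an aromatic carbon. Going by the values given here, the only step that bears on this change is the large one from compound 1 to compound 2, yet it already carries compound 2 to the top of the scale, so no further rise is possible there. Compound 3 is therefore expected to give about 92%, in the range 55% to 100%, and the expected step of a number 8 percentage points lower from compound 2 to compound 3 (within the scatter) is judged to lie within the scatter.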

Compound 3, a percentage reported as activity, at one concentration (the size of the read-out at that concentration, not a potency): 100%
Estimate against measurement, compound 3: 8 percentage points below; the measured number falls inside the stated range.
By their numbers in this assay, from the lowest: compound 1; then compounds 2 and 3 (each within the scatter of the next).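

In this assay, ethyl in place of hydrogen on a saturated chain carbon, four bonds along the chain from an aromatic carbon, gives no change at the digits printed from compound 2 to compound 3 (within the scatter) and so does not bring back the lower number of the propyl compound. Read directly, the whole lengthening of the chain gives a number 67 percentage points higher from compound 1 to compound 3 (beyond the scatter) and shows that the large difference from compound 1 survives further lengthening of the chain. Nothing available explains this behaviour of the chain.

Shorter chains such as ethyl or methyl remain open at this position, as do branched chains such as isobutyl. As far as these compounds go, it is also open whether a chain ending in an amine or a carboxylic acid would stay level with compound 2 and compound 3 or fall toward compound 1.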